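Series notes: amine variation on the shared core

A few compounds are considered here, and "the series" means these few. Any claim that something is new, unique, unknown or untested is made for them only; others in the source may bear on it.

Among the measured compounds shown here, compound 1 `CN(C)Cc1cc2c(N)nc(-c3ccco3)nc2s1` is the reference point here; in an assay on CHO-K1 cells for antagonist activity at adenosine receptor A1 (Homo sapiens), read by a beta-galactosidase reporter, with stated times of 15 min and 6 h (on this read-out lower numbers stand for stronger inhibition and higher numbers for weaker inhibition), compound 1 gives 3550 nM, the highest of the two numbers known. For the measured compounds named here, compound 2 `Nc1nc(-c2ccco2)nc2sc(CN3CCC(F)CC3)cc12` gives 740 nM, and the only measured step, a 4.8-fold lower number from compound 1 to compound 2 (0.68 log units; beyond the scatter), replaces the dimethylamino with a six-membered ring amine. Compound 3 `Nc1nc(-c2ccco2)nc2sc(CN3CCC(=O)CC3)cc12` has not been measured; it differs from compound 1 by 4-oxopiperidin-1-yl in place of dimethylamino on a saturated chain carbon bound to an aromatic carbon. Going by the values given here, the ring amine in compound 2 lowered the number modestly, so a step of similar direction is expected, a 2.7-fold lower number from compound 1 to compound 3 (0.44 log units; beyond the scatter), though the oxo ring has no direct precedent. Compound 3 is estimated at 1300 nM, within 400 nM to 4000 nM.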

Compound 3, inhibition constant: 2720 nM
For compound 3 the middle estimate is 2.1-fold (0.32 log units) below the measured one, and the stated range covers the measured number.
By their numbers in this assay, from the lowest: compound 2; then compounds 3 and 1 (each within the scatter of the next).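

In this assay, a six-membered ring amine on this saturated chain carbon does not by itself set a compound apart from the dimethylamino reference, with a 1.3-fold lower number from compound 1 to compound 3 (0.12 log units; within the scatter) in this case. The group on the ring does count, as shown by a 3.7-fold higher number from compound 2 to compound 3 (0.57 log units; beyond the scatter) at the same place, so 4-fluoropiperidin-1-yl and 4-oxopiperidin-1-yl are not interchangeable here. No available evidence accounts for this difference. As far as these compounds go, it remains open whether unsubstituted piperidin-1-yl would sit with compound 2 or compound 3. From the compounds shown here alone, the standing of a morpholine ring or 4-hydroxypiperidin-1-yl is also open.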